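The source may report more compounds than this note shows. Statements on the series, on what has been measured and on what is new or still open speak of the compounds shown alone.

Measured in a functional assay on Jurkat cells (Homo sapiens) for antiproliferative activity, read by MTT assay, with a stated time of 6 days; on this read-out lower numbers stand for stronger inhibition and higher numbers for weaker inhibition:
- Compound 1 `CC(=O)O[C@@H]1C=CC(=O)O[C@@H]1[C@@H](COC(=O)c1ccc(Cl)cc1)OC(C)=O`: 24400 nM
- Compound 2 `O=C1C=C[C@@H](OCc2ccccc2)[C@@H]([C@@H](COC(=O)/C=C/c2ccccc2)OCc2ccccc2)O1`: 4960 nM

Compound 2 at 4960 nM holds the lower of the two numbers, and its gap to compound 1 lies beyond the scatter. Within the data shown here, these two compounds differ in more than one place, so the series offers no measured single-change step to size the next one.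

Next for this assay is compound 3 `O=C1C=C[C@@H](OCc2ccccc2)[C@@H]([C@@H](CO)OCc2ccccc2)O1`. The change leading to it from compound 2 is hydrogen in place of (2-phenylethenyl)carbonyl on an oxygen on a saturated carbon. Here, (((2-phenylethenyl)carbonyl)oxy)methyl becomes hydroxymethyl.

Among the measured compounds shown here, with no measured precedent for this change, the expectation is a judgement only: a higher number, meaning weaker inhibition, by a step moderately beyond the scatter. The starting point is compound 2 at 4960 nM, and the upper part of the range is guided by compound 1 at 24400 nM. The expected step is a 2.2-fold higher number from compound 2 to compound 3 (0.35 log units; beyond the scatter). Compound 3 is expected at 11000 nM, with an estimated range of 3500 nM to 35000 nM.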

Compound 3, half-maximal inhibitory concentration: 12300 nM
Beside the measured number, compound 3's estimate is 1.1-fold (0.05 log units) below it; measured number inside the range.
By their numbers in this assay, from the lowest: compound 2; then compounds 3 and 1 (each within the scatter of the next).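

In this assay the series now has its first measured single-change step: replacing (2-phenylethenyl)carbonyl with hydrogen on the oxygen on a saturated carbon gives a 2.5-fold higher number from compound 2 to compound 3 (0.39 log units; beyond the scatter) and so puts a size on this position. Compound 3 still gives a measured value of 12300 nM with a free hydroxymethyl, which shows that a number in this read-out does not depend on the (((2-phenylethenyl)carbonyl)oxy)methyl group, although that group goes with the lower number of this pair. Nothing available bears on the reason for this step.

One step cannot separate the contribution of the aromatic ring from that of the double bond or the carbonyl, and a 3-phenylpropanoyl group on the same oxygen would test the double bond directly. As far as these compounds go, how an amine or a carboxylic acid would read in place of the hydroxy of compound 3 remains open, as does the effect of any single change to the two benzyl groups on the shared core.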